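The source may report more compounds than this note shows. Statements on the series, on what has been measured and on what is new or still open speak of the compounds shown alone.

Working notes on the series. The shared core of compound 1 `O=C1COc2ccc(-c3cnc(Cl)c(NS(=O)(=O)c4ccc(F)cc4)c3)cc2N1c1ccccc1` carries a phenyl on the ring amide nitrogen; compound 2 `O=C1COc2ccc(-c3ccc(O)cc3)cc2N1` has no substituent there, and compound 3 `O=C1COc2ccc(-c3cnc4ccccc4c3)cc2N1c1ccc(Cl)cc1` carries a chlorophenyl. In a functional assay on HCT-116 cells (Homo sapiens) for antiproliferative activity, read by MTT assay, with a stated time of 72 h (on this read-out higher numbers stand for weaker inhibition and lower numbers for stronger inhibition), compound 1 gives 39800 nM. Compound 3 gives 36100 nM in this assay, a number that lies within the scatter of that for compound 1, so the two cannot be separated. Among the measured compounds shown here, compound 2 gives only a limit of the assay, > 40000 nM in this assay; the series thus sits against (the limit of > 40000 nM in this assay, at which 1 of the 3 values shown sits), and every value so far is weak.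

The next step goes from compound 1 to compound 4 `O=C1COc2ccc(-c3cnc(Cl)c(NS(=O)(=O)c4ccc(F)cc4)c3)cc2N1C1CC1`, which differs by cyclopropyl in place of phenyl on an amide-type nitrogen in a ring. For the measured compounds named here, no measured step between compounds differing in one place is available, so the size of this change has no precedent here. Given that compound 1 gives 39800 nM and the whole series lies at the top of the range, the expected step from compound 1 to compound 4 is a 1.0-fold higher number from compound 1 to compound 4 (0.00 log units; within the scatter), i.e. none beyond the scatter. Compound 4 is estimated at 40000 nM, with a range of 18000 nM to 80000 nM in this assay.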

Compound 4, half-maximal inhibitory concentration: 12400 nM
Compound 4: middle estimate off by 3.2-fold (0.51 log units), on the high side; measured number below the stated range.
By their numbers in this assay, from the lowest: compound 4; then compounds 3 and 1 (each within the scatter of the next). At a limit, above all of these: compound 2.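

In this assay the substituent on the amide-type nitrogen in a ring turns out to matter, with cyclopropyl in place of phenyl giving a 3.2-fold lower number from compound 1 to compound 4 (0.51 log units; beyond the scatter). Among the compounds shown here, as the only measured step, and one beyond the scatter, it shows that phenyl is not needed at this position for the activity seen and that a smaller carbon ring is accepted there, although the number stays modest. Compound 2 remains a limit of the assay: the limit of > 40000 nM in this assay, at which 1 of the 4 values shown sits.

One step cannot tell whether the shift follows from ring size, from the loss of the aromatic ring or from something else, and compound 2 and compound 3 differ from compound 1 in more than one place, so they do not help. Also open, from the compounds shown here alone, is how a methyl, an isopropyl, a cyclobutyl or an aminoethyl chain would behave on this nitrogen.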